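The source may report more compounds than this note shows. Statements on the series, on what has been measured and on what is new or still open speak of the compounds shown alone.

Measured compounds:
- compound 1, `Cc1ccnc(/C(N)=N/NC(=S)N2CCSCC2)c1`: in a functional assay on HeLa cells (Homo sapiens) for cytotoxicity, read by MTT assay, with a stated time of 72 h, tested at 10 uM (on this read-out higher numbers stand for more inhibition of growth at the one concentration tested and lower numbers for less inhibition of growth), compound 1 gives 39.2%
- compound 2, `Cc1ccnc(/C(N)=N/NC(=S)N2CCCC2)c1`: compound 2 gives 67%
- compound 3, `N/C(=N\NC(=S)N1CCN(c2ccccn2)CC1)c1ccc(F)cn1`: compound 3 gives 80%

Compound 3 has the highest of the three numbers; its nearest neighbour is compound 2, and the most distant is compound 1, both of these gaps lying beyond the scatter.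

Compound 4, `Cc1cccc(/C(N)=N/NC(=S)N2CCN(c3ccccn3)CC2)n1`, has not yet been measured. It differs from compound 3 in one place: 6-methylpyridin-2-yl in place of 5-fluoropyridin-2-yl on a carbon with a double bond to nitrogen.

Among the compounds with values here, the one measured step of a single change, a number 27.8 percentage points higher from compound 1 to compound 2 (beyond the scatter), concerns the group on the thiocarbonyl carbon, not the aryl group on the carbon with a double bond to nitrogen, so it does not bear on this change. Within the data shown here, compounds 1 and 2 carry a differently substituted pyridinyl ring than compound 3, but they also differ at the thiocarbonyl carbon, and no single step separates that aryl change. Among the measured compounds shown here, no measured step therefore informs the change from compound 3 to compound 4, and a step of no more than modest size in this assay is expected, with the direction unknown and a somewhat lower number the more cautious guess.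

For compound 4 the estimated value is 70%, with a range from 45% to 90%, which amounts to an expected step of a number 10 percentage points lower from compound 3 to compound 4 (within the scatter).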

Compound 4, percent growth inhibition at one concentration: 72.8%
The estimate for compound 4 lay 2.8 percentage points below the measured number, within the range that was stated.
By their numbers in this assay, from the lowest: compound 1; then compounds 2, 4 and 3 (each within the scatter of the next, the first and the last beyond it).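

In this assay, 6-methylpyridin-2-yl in place of 5-fluoropyridin-2-yl on the carbon with a double bond to nitrogen gives a number 7.2 percentage points lower from compound 3 to compound 4 (within the scatter), the only single-change reading at this position among the compounds shown. With the group on the thiocarbonyl carbon held constant, this pair shows that the read-out does not separate these two aryl groups, which match in heavy atoms and in hydrogen-bond donors and acceptors, although one carries fluorine and the other a methyl group. Nothing available accounts for this outcome at the level of mechanism.

As far as these compounds go, it remains open whether a pyridin-2-yl ring bearing an amine, a carboxylic acid or a longer alkyl chain would also leave the read-out within the scatter at this place, or whether a phenyl ring would do the same. From the compounds shown here alone, it is also open whether the same tolerance holds when pyrrolidin-1-yl or thiomorpholin-4-yl sits on the thiocarbonyl carbon, since the step between those two groups lies beyond the scatter and the aryl change has been read only with the group shared by compound 3 and compound 4.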